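Methyl for Chloro: Expectation for Compound 4

A few compounds are considered here, and "the series" means these few. Any claim that something is new, unique, unknown or untested is made for them only; others in the source may bear on it.

Compound 1 `CS(=O)(=O)Nc1ccc(Cl)c2c1CCCC2c1c[nH]cn1` gives 4.35 in a functional assay on Urethra for agonist activity at Alpha-1A adrenergic receptor (Oryctolagus cuniculus) (on this read-out lower numbers stand for lower potency and higher numbers for higher potency (the scale is a negative logarithm)), the lowest of the two single numbers recorded. Compound 2 `CC(C)S(=O)(=O)Nc1cccc2c1CCCC2c1c[nH]cn1` reaches 5.17, a gap beyond the usual scatter. Compound 3 `CS(=O)(=O)Nc1cccc2c1CCC=C2c1c[nH]cn1` has no single number but several entries, 4.67; 4.54 (2 entries), that is the several entries of compound 3 in this assay, 4.67; 4.54 (2 entries), which sit close together. Compound 4 `Cc1ccc(NS(C)(=O)=O)c2c1C(c1c[nH]cn1)CCC2` is not yet measured; it differs from compound 1 by methyl in place of chloro on an aromatic carbon. Among the compounds with values here, no pair of measured compounds differs at this one place, so the measured data give no direct guide to the size of such a step. Compound 4 is expected to move by a number 0.20 log units higher from compound 1 to compound 4 (within the scatter), a shift judged to lie within the scatter. Compound 4 is therefore estimated at 4.55, with a range from 4 to 5.1.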

Compound 4, negative logarithm of the half-maximal effective concentration: 4.4
Estimate against measurement, compound 4: 0.15 log units above; measured number inside the range.
By their numbers in this assay, from the lowest: compounds 1 and 4 (each within the scatter of the next); then compound 2.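

In this assay, within the data shown here, methyl in place of chloro on the aromatic carbon para to a methanesulfonamido group gives a number 0.05 log units higher from compound 1 to compound 4 (within the scatter), the only step read at this position. On this read-out, the two groups are therefore not told apart at this carbon in the core of compound 1. Nothing measured here bears on why this is so. The compounds shown leave open whether an amine or a carboxylic acid at the same carbon would also stay within the scatter of compound 1.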